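The source may report more compounds than this note shows. Statements on the series, on what has been measured and on what is new or still open speak of the compounds shown alone.

In an ADME assay on Vero cells (Chlorocebus sabaeus) for cytotoxicity, read by neutral red uptake (on this read-out higher numbers stand for weaker inhibition and lower numbers for stronger inhibition), compound 1 (`COC(/C=C/c1ccc(O)cc1)=C1\C(=O)C=C(C)C1=O`) gives 3.7 ug/mL while compound 2 (`CC(=O)OC(/C=C/c1ccccc1)=C1\C(=O)C=C(C)C1=O`) gives 5.5 ug/mL and compound 3 (`COC(/C=C/c1ccco1)=C1\C(=O)C=C(C)C1=O`) gives 3.3 ug/mL on the same read-out. All three numbers lie within the usual scatter of one another, so compound 1 cannot be told apart from the other two. Compound 4 (`COC(/C=C/c1ccc(OC)cc1)=C1\C(=O)C=C(C)C1=O`) is compound 1 with one change (methyl in place of hydrogen on an oxygen on an aromatic ring) that turns hydroxy into methoxy. Among the measured compounds shown here, no measured pair shows this change alone. Compound 3 carries no hydroxy and still gives 3.3 ug/mL here, so no step beyond the scatter is expected in this assay for this change. The estimated step (a 1.1-fold higher number from compound 1 to compound 4 (0.03 log units; within the scatter)) is small. For compound 4 the expected value is 4 ug/mL with an estimated range from 2 ug/mL to 8 ug/mL in this measurement.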

Compound 4, half-maximal inhibitory concentration: 5 ug/mL
Beside the measured number, compound 4's estimate is 1.3-fold (0.10 log units) below it; measured number inside the range.
By their numbers in this assay, from the lowest: compounds 3, 1, 4 and 2 (each within the scatter of the next).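

In this assay, the step for methyl in place of hydrogen on an oxygen on an aromatic ring can now be read directly: a 1.4-fold higher number from compound 1 to compound 4 (0.13 log units; within the scatter). This single-change pair shows that, on the core of compound 1, turning hydroxy into methoxy gives no step beyond the scatter, so the hydrogen on this oxygen makes no measurable difference here. Nothing shown gives a reason for this result. As far as these compounds go, whether a longer chain on this oxygen would give a step beyond the scatter remains open. So does the effect of an amine or a carboxylic acid in place of the hydroxy.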